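The compounds below may be only part of what the source reports. "The series", "measured", "known", "first", "only" and "open" are said of these compounds alone.

Measured compounds:
compound 1 `O=C(O)Cc1sc(C(c2ccc(F)cc2)c2ccc(F)cc2)nc1-c1ccnc(F)c1` — 0.48 nM
compound 2 `NS(=O)(=O)c1ccc(-c2nc(C(c3ccc(F)cc3)c3ccc(F)cc3)sc2CC(=O)O)cc1` — 1500 nM
compound 3 `O=C(O)Cc1sc(C2COc3ccccc3O2)nc1-c1ccc(Cl)cc1` — 500 nM

In an in vitro assay on HEK385-7 cells for displacement of a labelled ligand from prostaglandin D2 receptor 2 (Homo sapiens) (on this read-out lower numbers stand for stronger inhibition and higher numbers for weaker inhibition), compound 1 gives 0.48 nM, the lowest of the three numbers. Compound 3 gives 500 nM, far above it, and compound 2 gives 1500 nM, further above still. Among the measured compounds shown here, the one step measured between compounds that differ in a single place is a 3100-fold higher number from compound 1 to compound 2 (3.49 log units; beyond the scatter), a very large loss when the 2-fluoropyridin-4-yl group is exchanged for a 4-sulfamoylphenyl group.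

Compound 4 `O=C(O)Cc1sc(C(c2ccc(F)cc2)c2ccc(F)cc2)nc1-c1ccnc(Cl)c1` differs from compound 1 as follows: chloro in place of fluoro on an aromatic carbon. The halogen on the six-membered aromatic ring with 1 nitrogen is exchanged, the rest of the molecule remaining as in compound 1.

For the measured compounds named here, no measured step bears directly on this change. The step from compound 1 to compound 2 replaces the whole ring and so says nothing about swapping one halogen for another at one carbon of it. Going by the values given here, compound 3 carries a chloro, but on a different ring and within a differently built molecule, and no single-place step links it to compound 1. With nothing to suggest a shift, a change within the usual scatter is the natural expectation. Compound 4 is therefore expected to give 0.6 nM, in a range from 0.2 nM to 2 nM. This expectation amounts to a 1.3-fold higher number from compound 1 to compound 4 (0.10 log units; within the scatter).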

Compound 4, half-maximal inhibitory concentration: 3.1 nM
For compound 4 the middle estimate is 5.2-fold (0.71 log units) below the measured one; the whole stated range lies below it.
By their numbers in this assay, from the lowest: compound 1; then compound 4; then compound 3; then compound 2.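

In this assay, the exchange of fluoro for chloro on the aromatic carbon next to the ring nitrogen gives a 6.5-fold higher number from compound 1 to compound 4 (0.81 log units; beyond the scatter) and so is not a silent swap: a single halogen at this carbon moves the read-out, which the earlier exchange of the whole ring could not show. This loss is small beside the ring exchange, as the 2-chloropyridin-4-yl group still gives a 480-fold lower number from compound 2 to compound 4 (2.68 log units; beyond the scatter) and so keeps most of the advantage over the 4-sulfamoylphenyl group. Nothing available here accounts for the difference between fluoro and chloro at this carbon.

With only two halogens at this carbon, the compounds shown give no trend for the position, and it remains open whether a bromo, a methyl or a methoxy group there would fall near fluoro, near chloro or elsewhere. They also leave open whether the same exchange of fluoro for chloro would cost as much with a different group elsewhere on the shared core.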